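A few compounds are considered here, and "the series" means these few. Any claim that something is new, unique, unknown or untested is made for them only; others in the source may bear on it.

Three analogues of the shared core carry a five-membered or fused heteroaryl on the pendant phenyl. Compound 1 `Cc1ccccc1-n1nc(C)c2c1NC(=O)[C@H](C)S[C@@H]2c1ccc(-c2ccoc2)cc1` gives 40% in an assay on isolated protein for agonist activity at Bile acid receptor (Homo sapiens), read by AlphaScreen, with a stated time of 30 min; a higher number here means a larger maximal response, a lower number a smaller maximal response. Compound 2 `Cc1ccccc1-n1nc(C)c2c1NC(=O)[C@H](C)S[C@@H]2c1ccc(-c2cc3ccccc3o2)cc1` gives 17% in this assay, and compound 3 `Cc1ccccc1-n1nc(C)c2c1NC(=O)[C@H](C)S[C@@H]2c1ccc(-c2ccsc2)cc1` gives 68% in this assay. Compound 3 stands highest of the three: a number 28 percentage points higher from compound 1 to compound 3 (beyond the scatter) and a number 51 percentage points higher from compound 2 to compound 3 (beyond the scatter). Compound 4 `COc1ccccc1-c1ccc([C@H]2S[C@@H](C)C(=O)Nc3c2c(C)nn3-c2ccccc2C)cc1` differs from compound 3 by 2-methoxyphenyl in place of thiophen-3-yl on an aromatic carbon. Among the compounds with values here, no measured step covers a six-membered carbon-only ring at this position; the nearest comparison is a number 23 percentage points lower from compound 1 to compound 2 (beyond the scatter), where the larger entering group lowered the response. On that basis a modest decrease is expected, a number 30 percentage points lower from compound 3 to compound 4 (beyond the scatter). Compound 4 is therefore estimated at 38% in this assay, with a range of 15% to 62%.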

Compound 4, largest response reached (reported as efficacy), in percent of the reference or control that the assay uses: 50%
Compound 4: middle estimate off by 12 percentage points, on the low side; the range from low to high includes it.
By their numbers in this assay, from the lowest: compound 2; then compounds 1 and 4 (each within the scatter of the next); then compound 3.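

With a six-membered carbon-only ring at this position, this assay shows (a number 18 percentage points lower from compound 3 to compound 4 (beyond the scatter)) against thiophen-3-yl and (a number 33 percentage points higher from compound 2 to compound 4 (beyond the scatter)) against 1-benzofuran-2-yl, so 2-methoxyphenyl falls between those two groups. Against furan-3-yl the change is a number 10 percentage points higher from compound 1 to compound 4 (within the scatter) and sets no order between these two groups. No available evidence explains these differences.

On these data alone, whether the response of 2-methoxyphenyl follows from the methoxy group or from the carbon-only ring stays open. So does the reading for an unsubstituted phenyl, a pyridine ring or an aminomethyl group at this position.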